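Swapping Hydroxymethyl for Chloro on a Glycine Transporter Ligand

This account rests on a few compounds, and the source may have more. Where it says the series, first, only, none or still open, it means among the compounds named here.

Measured compounds:
compound 1 `CCc1nnc(-c2ccc(-c3ccccc3)cn2)n1-c1ccccc1F`: 700 nM
compound 2 `CCc1nnc(N2CCC(c3ccccc3)CC2)n1-c1ccccc1F`: 3700 nM
compound 3 `CCc1nnc(-c2ccc(-c3ccccc3)cc2)n1-c1cccc(CO)c1C`: 250 nM

In an assay on C6 glioma cells for displacement of a labelled ligand from sodium- and chloride-dependent glycine transporter 1 (Rattus norvegicus), read by scintillation counting, with stated times of 30 min and 10 min (on this read-out higher numbers stand for weaker inhibition and lower numbers for stronger inhibition), compound 1 gives 700 nM. Compound 2, in this assay, gives 3700 nM. Compound 3 gives 250 nM in this assay, the lowest of the three numbers; its gap to compound 1 and its wider gap to compound 2 both lie beyond the scatter, so compound 3 is the strongest inhibitor among the measured compounds.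

Compound 4 `CCc1nnc(-c2ccc(-c3ccccc3)cc2)n1-c1cccc(Cl)c1C` is not yet measured. It differs from compound 3 in one place: chloro in place of hydroxymethyl on an aromatic carbon. Among the measured compounds shown here, no measured pair shows this change on its own, so the expectation rests on compound 3 alone, with the value 250 nM as the anchor. The step of a 1.1-fold lower number from compound 3 to compound 4 (0.06 log units; within the scatter) is expected to be small, in either direction, and most likely not beyond the scatter. Compound 4 is therefore estimated at 220 nM, with a range from 60 nM to 800 nM.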

Compound 4, half-maximal inhibitory concentration: 2200 nM
Estimate against measurement, compound 4: 10-fold (1.00 log units) below, outside the stated range (above it).
By their numbers in this assay, from the lowest: compound 3; then compound 1; then compounds 4 and 2 (each within the scatter of the next).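

Hydroxymethyl and chloro are not interchangeable at this position: going from 3-(hydroxymethyl)-2-methylphenyl to 3-chloro-2-methylphenyl gives an 8.8-fold higher number from compound 3 to compound 4 (0.94 log units; beyond the scatter) in this assay and so weakens inhibition beyond the scatter. The earlier compounds shown here could not show this, since none of them forms a pair differing only at this place. Hydroxymethyl brings a hydrogen-bond donor and acceptor and chloro brings neither, but no measurement here links that difference to the loss, and nothing available explains it.

Still open, going by these compounds, is whether another group at this place, such as an amine, a methoxy group or a carboxylic acid, would hold the strength of compound 3 or lose it as compound 4 does. Also open, on these data alone, is whether the same swap would have a step of similar size on a different core.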